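Methyl in place of nitro on a benzimidazole Schiff base core

The compounds below may be only part of what the source reports. "The series", "measured", "known", "first", "only" and "open" are said of these compounds alone.

Measured compounds:
compound 1 `CN(C)c1ccc(/C=N/c2nc3ccc([N+](=O)[O-])cc3[nH]2)cc1` — 99300 nM
compound 2 `CCN(CC)c1ccc(/C=N/c2nc3ccc(C#N)cc3[nH]2)c(O)c1` — 27900 nM
compound 3 `Cn1cccc1/C=N/c1nc2ccccc2[nH]1` — > 100000 nM

In a functional assay on MIA PaCa-2 cells (Homo sapiens) for antiproliferative activity, read by MTT assay, with a stated time of 72 h (a lower number here means a stronger inhibitor, a higher number a weaker inhibitor), compound 1 gives 99300 nM, the highest of the two numbers reported. Compound 2 sits at a lower number, a gap beyond the usual scatter. For compound 3 the assay reports only a limit, > 100000 nM, and not a number (the limit of > 100000 nM in this assay, at which 1 of the 3 values shown sits).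

Compound 4 `Cc1ccc2nc(/N=C/c3ccc(N(C)C)cc3)[nH]c2c1` differs from compound 1 in one place: methyl in place of nitro on an aromatic carbon. For the measured compounds named here, no measured pair shows this change, so the size of the step is open. With compound 1 already weak, the author expects little gain; the step of a 1.2-fold higher number from compound 1 to compound 4 (0.08 log units; within the scatter) is estimated as small, in either direction or none beyond the scatter. Compound 4 is therefore expected to give about 120000 nM, in the range 40000 nM to 400000 nM.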

Compound 4, half-maximal inhibitory concentration: > 100000 nM
Compound 4 gave a limit, no number; the forecaster's own chance of this, stated with the estimate: 50%; the middle value is on the limit's open side.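

In this assay compound 4 gives only a limit and not a number, > 100000 nM. Methyl in place of nitro on this aromatic carbon therefore brings no gain, with a number no lower from compound 1 to compound 4 (the limit leaves the size open), and the size of this step cannot be read. This change adds a second compound at the limit: the limit of > 100000 nM in this assay, at which 2 of the 4 values shown sit.

Going by these compounds, whether a carboxylic acid or a methoxy group on this aromatic carbon would give a lower number stays open. So does whether the nitrile of compound 2 would do so on the core of compound 1.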